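Swapping an aryl group on a boron-containing anilide series

This account rests on a few compounds, and the source may have more. Where it says the series, first, only, none or still open, it means among the compounds named here.

Measured so far:
Compound 1, `COc1cccc(-c2cccc(NC(=O)CCc3cccc4c3COB4O)c2)c1`, gives 78000 nM in a functional assay on SK-OV-3 cells (Homo sapiens) for antiproliferative activity, read by MTT assay, with a stated time of 72 h; a lower number here means a stronger inhibitor, a higher number a weaker inhibitor.
Compound 2, `CC(=O)c1ccc(-c2cccc(NC(=O)CCc3cccc4c3COB4O)c2)cc1`, gives 57000 nM in this assay.
Compound 3, `COc1cccc(-c2cccc(NC(=O)CCc3cccc4c3C(O)OC4)c2)c1`, gives 61000 nM in this assay.

Compound 1 and compound 2 share a core and differ in one place: 4-acetylphenyl in place of 3-methoxyphenyl on an aromatic carbon. That change produced a 1.4-fold lower number from compound 1 to compound 2 (0.14 log units; within the scatter), so the two compounds cannot be told apart by their numbers. Compound 3 carries the same 3-methoxyphenyl group as compound 1 but sits on a different core; how the two cores differ is not broken down here, and the values of compound 1 and compound 3 lie within the scatter of each other, as do those of compound 3 and compound 2.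

Compound 4, `CC(=O)c1ccc(-c2cccc(NC(=O)CCc3cccc4c3C(O)OC4)c2)cc1`, has not yet been measured. It stands to compound 3 as compound 2 stands to compound 1: 4-acetylphenyl in place of 3-methoxyphenyl on an aromatic carbon. The two places are described in the same words, so this is the same change made on the other core.

Because a 1.4-fold lower number from compound 1 to compound 2 (0.14 log units; within the scatter) was within the scatter, the expected step on the other core is a similarly small one, a 1.4-fold lower number from compound 3 to compound 4 (0.13 log units; within the scatter). Compound 4 is therefore estimated to give 45000 nM in this assay, most likely somewhere between 20000 nM and 100000 nM. Whether this holds is what the measurement will show.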

Compound 4, half-maximal inhibitory concentration: 41000 nM
The estimate for compound 4 lay 1.1-fold (0.04 log units) above the measured number; low and high end bracket the measured number.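

In this assay, putting 4-acetylphenyl in place of 3-methoxyphenyl on the second core gave a 1.5-fold lower number from compound 3 to compound 4 (0.17 log units; within the scatter), and exchanging the core while keeping 4-acetylphenyl gave a 1.4-fold lower number from compound 2 to compound 4 (0.14 log units; within the scatter), so neither change separates the two compounds it joins. The aryl swap behaved alike on both cores, in the limited sense that it stayed small each time: the same change on two cores in this assay, a 1.4-fold lower number (0.14 log units; within the scatter) from compound 1 to compound 2 and a 1.5-fold lower number (0.17 log units; within the scatter) from compound 3 to compound 4, 1.1-fold (0.04 log units) apart, within the scatter of two such steps This does not show that the swap has a real effect of its own that travels from core to core, for every step here lies within the scatter, and two small steps that agree say only that nothing large happened on either core; a single change on two cores is also too little to support a general rule for the series.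

The compounds shown leave open whether a different kind of group in place of the 4-acetylphenyl, such as an amine or a carboxylic acid, would move the number beyond the scatter, and whether such a larger step would then be the same on both cores. They also leave open what a longer chain in place of the present saturated chain would do on either core.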